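Carbamoyl in place of cyano: expected liver stability

The compounds below may be only part of what the source reports. "The series", "measured", "known", "first", "only" and "open" are said of these compounds alone.

Compound 1 `CC(=O)c1ccc(NC(=O)Nc2ccc(F)c(C(F)(F)F)c2)cc1` gives 16 uL/min in an ADME assay on microsomes from liver (Homo sapiens) for metabolic stability, using NADPH, with a stated time of 60 min; on this read-out lower numbers stand for slow clearance and higher numbers for fast clearance.
Compound 2 `N#Cc1ccc(NC(=O)Nc2ccc(F)c(C(F)(F)F)c2)cc1` gives < 7 uL/min in this assay; this is a limit of the assay, not a number.

Compound 2 therefore stands at the low edge of what this assay reports (the limit of < 7 uL/min in this assay, at which 1 of the 2 values shown sits). Among the measured compounds shown here, the one measured step goes an at least 2.2-fold lower number from compound 1 to compound 2 (0.35 log units; beyond the scatter), so compound 2 sits on the slow-clearance side of compound 1, though by an amount known only as a lower bound.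

The step to compound 3 `NC(=O)c1ccc(NC(=O)Nc2ccc(F)c(C(F)(F)F)c2)cc1` makes a different change: carbamoyl in place of cyano on an aromatic carbon

For the measured compounds named here, no measured step exchanges cyano for carbamoyl, so the only guidance is that compound 2 already lies at the limit and that the exchange of acetyl for cyano moved the number down rather than up. Compound 3 is therefore expected to stay near the limit, with a step that the limit leaves unreadable from compound 2 to compound 3 that is expected to be no larger than the scatter and as likely to end in another limit as in a number. The estimate for compound 3 in this assay is 6 uL/min, within 3 uL/min to 14 uL/min.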

Compound 3, intrinsic clearance in a liver preparation (reported as CLH), per the amount of preparation that the assay uses in the Homo sapiens assay: 28 uL/min
Estimate against measurement, compound 3: 4.7-fold (0.67 log units) below, outside the stated range (above it).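

Compound 2 stands at a limit of the Homo sapiens assay, not at a number: the limit of < 7 uL/min in the Homo sapiens assay, at which 1 of the 3 values shown sits.

On this aromatic carbon, para to a large group, the Homo sapiens assay shows that carbamoyl in place of cyano is no silent exchange, giving an at least 4.0-fold higher number from compound 2 to compound 3 (0.60 log units; beyond the scatter), while amino in place of methyl on the carbonyl carbon gives a 1.8-fold higher number from compound 1 to compound 3 (0.24 log units; within the scatter), so the carbamoyl and acetyl compounds are not told apart and only the cyano compound stands clear of both. In a physicochemical assay for lipophilicity, read by HPLC, measured as octanol-water partition, at pH 7.2 (a lower number here means a more polar compound, a higher number a more lipophilic compound), compound 2 gives 3.8 and compound 3 gives 2.7, so in this one pair the lower distribution coefficient goes with the higher clearance number, and clearance at this position does not simply fall as the distribution coefficient falls.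

A single pair cannot tell whether the two read-outs are linked at all, or whether the rise in clearance belongs to the carbamoyl group itself. The compounds shown also leave open where a carboxylic acid, a methyl ester or a sulfonamide on the same carbon would fall relative to the nitrile and the two carbonyl groups.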